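Replacing a methoxyphenyl with a fluorophenyl on the shared core

The source may hold more compounds than are shown below. What is called first, only, known or untested is meant among the compounds shown, and "the series" means these compounds.

Compound 2 `COc1ccc(-c2cc(N3CCC(CNS(N)(=O)=O)CC3)ncn2)cc1` carries a 4-methoxyphenyl on the shared core, while compound 1 `CC(C)(C)c1ccc(-c2cc(N3CCC(CNS(N)(=O)=O)CC3)ncn2)cc1` carries a tert-butyl and compound 3 `NS(=O)(=O)NCC1CCN(c2cc(-c3ccc(C(F)(F)F)cc3)ncn2)CC1` a trifluoromethyl on the same aryl. In a functional assay on M21 cells (Homo sapiens) for antiproliferative activity, read by sulforhodamine B assay, with a stated time of 48 h (a higher number here means a weaker inhibitor of growth, a lower number a stronger inhibitor of growth), compound 2 gives > 100000 nM, which is a limit of the assay and not a number. Compound 1 gives 19300 nM in this assay, and compound 3 gives 43100 nM. Compound 2 therefore stands at the weak end of the three, as the step of an at least 5.1-fold higher number from compound 1 to compound 2 (0.71 log units; beyond the scatter) and the step of an at least 2.3-fold lower number from compound 2 to compound 3 (0.36 log units; beyond the scatter) both show, with the limit of > 100000 nM in this assay, at which 1 of the 3 values shown sits, marking where its value sits.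

Compound 4 `NS(=O)(=O)NCC1CCN(c2cc(-c3ccccc3F)ncn2)CC1` is the unmeasured compound. The change is 2-fluorophenyl in place of 4-methoxyphenyl on an aromatic carbon. Among the compounds with values here, none of the measured steps swaps an aryl substituent for a fluorine, so the expectation rests on the two steps that leave compound 2: both go away from the methoxy and both lower the number, while the step of a 2.2-fold higher number from compound 1 to compound 3 (0.35 log units; beyond the scatter) shows that the choice of substituent matters only modestly among the rest. A modest move to a lower number is expected, as an at least 2.0-fold lower number from compound 2 to compound 4 (0.30 log units; that floor lies within the scatter). Compound 4 is thus estimated at 50000 nM in this assay, between 15000 nM and 150000 nM, with a real chance that only a limit is again reported.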

Compound 4, concentration for 50% growth inhibition: > 100000 nM
Compound 4: a limit, no number (the forecaster's own chance of this, stated with the estimate: 40%); middle value at least 2.0-fold (0.30 log units) from the limit.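

In this assay, within the data shown here, compound 2 and compound 4 each give only a limit of the assay and not a number, so no step between them can be read: the limit of > 100000 nM in this assay, at which 2 of the 4 values shown sit. The compounds shown leave open how far 2-fluorophenyl and 4-methoxyphenyl actually differ on the shared core.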